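The compounds below may be only part of what the source reports. "The series", "measured", "known", "first", "only" and "open" are said of these compounds alone.

Of the compounds shown here, three that share one core have been tested in a functional assay on HepG2 cells (Homo sapiens) for antiproliferative activity, read by MTT assay, with a stated time of 48 h; on this read-out higher numbers stand for weaker inhibition and lower numbers for stronger inhibition. Compound 1 `COc1cc(-c2nnc(SCC(=O)c3ccc(F)cc3)n2N)cc(OC)c1OC` gives 90400 nM in this assay. Compound 2 `COc1cc(-c2nnc(SCC(=O)c3cccc(Br)c3)n2N)cc(OC)c1OC` gives 56000 nM in this assay. Between them the step was a 1.6-fold lower number from compound 1 to compound 2 (0.21 log units; within the scatter). Compound 3 `COc1cc(-c2nnc(SCC(=O)c3ccc(F)c(F)c3)n2N)cc(OC)c1OC` reaches only the limit of this assay, reported as > 100000 nM. Compound 3 therefore stands at the limit of > 100000 nM in this assay, at which 1 of the 3 values shown sits, so only a floor for its number is known. Against compound 1 the step was an at least 1.1-fold higher number from compound 1 to compound 3 (0.04 log units; that floor lies within the scatter), and against compound 2 it was an at least 1.7-fold higher number from compound 2 to compound 3 (0.25 log units; that floor lies within the scatter). Compound 4 `COc1ccc(C(=O)CSc2nnc(-c3cc(OC)c(OC)c(OC)c3)n2N)cc1` has not yet been measured. It differs from compound 3 in one place: 4-methoxyphenyl in place of 3,4-difluorophenyl on a carbonyl carbon. The measured steps that bear on this change are the exchanges of the ring on the carbonyl carbon and the added fluoro, and none of them moved the number beyond the scatter. A step of an at least 1.2-fold lower number from compound 3 to compound 4 (0.09 log units; that floor lies within the scatter) is therefore expected in this assay, with no clear direction. Compound 4 is expected to come in near 80000 nM, within a range from 30000 nM to 200000 nM, with a fair chance that this assay again reports only a limit for it.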

Compound 4, half-maximal inhibitory concentration: > 100000 nM
Compound 4: a limit, no number (the forecaster's own chance of this, stated with the estimate: 40%); at least 1.2-fold (0.09 log units) between middle value and limit.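

In this assay compound 4, with 4-methoxyphenyl on the carbonyl carbon, gives > 100000 nM, which is a limit and not a number. Against the two compounds that do have numbers, the result is an at least 1.7-fold higher number from compound 2 to compound 4 (0.25 log units; that floor lies within the scatter) and an at least 1.1-fold higher number from compound 1 to compound 4 (0.04 log units; that floor lies within the scatter), so 4-methoxyphenyl is not yet separated from either 3-bromophenyl or 4-fluorophenyl, while the step from compound 3 cannot be read at all, as both of its ends are limits. What is new is that a ring with a methoxy group, like the 3,4-difluorophenyl ring of compound 3, yields no number, so the limit now holds more than one member of this small series: the limit of > 100000 nM in this assay, at which 2 of the 4 values shown sit.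

As far as these compounds go, it remains open whether any group on this ring can move the number clearly beyond the scatter, and a phenyl ring carrying an amine or a carboxylic acid would test that. From the compounds shown here alone, it is equally open what a longer chain in place of the saturated chain carbon, or a change elsewhere on the shared core, would do to the number.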